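The source may hold more compounds than are shown below. What is called first, only, known or untested is meant among the compounds shown, and "the series" means these compounds.

Working notes on the series. In an ADME assay on HCT-116 cells (Homo sapiens) for cytotoxicity, read by MTT assay, with a stated time of 72 h (a higher number here means a weaker inhibitor, a lower number a stronger inhibitor), compound 1 `CCc1cccc(NC(=O)c2cccc(/C=C3\CC(=O)N(c4ccccc4)C3=O)c2)c1` gives 81200 nM. Compound 2 `Cc1ccc(NC(=O)c2cccc(/C=C3\CC(=O)N(c4ccccc4)C3=O)c2)cc1` in this assay gives > 100000 nM, which is a limit of the assay and not a number. Compound 3 `O=C(Nc1ccc(F)cc1)c1cccc(/C=C2\CC(=O)N(c3ccccc3)C2=O)c1` in this assay gives > 100000 nM, again a limit of the assay and not a number. Across the measured pairs the steps read an at least 1.2-fold higher number from compound 1 to compound 2 (0.09 log units; that floor lies within the scatter), an at least 1.2-fold higher number from compound 1 to compound 3 (0.09 log units; that floor lies within the scatter) and a step that the two limits leave unreadable from compound 2 to compound 3; the picture is shaped by the limit of > 100000 nM in this assay, at which 2 of the 3 values shown sit, so compound 3 stands only at a limit, with one further value shown also being a limit.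

The next compound, compound 4 `O=C(Nc1ccc(Cl)cc1)c1cccc(/C=C2\CC(=O)N(c3ccccc3)C2=O)c1`, differs from compound 3 by chloro in place of fluoro on an aromatic carbon. Among the measured compounds shown here, no measured pair swaps one halogen for another; the closest comparisons are the step from compound 2 to compound 3 , whose size is unreadable, and the two steps from compound 1 , each with a floor inside the scatter. Nothing here points to a step beyond the scatter in this assay in either direction, and a reading that again sits at the limit seems the most probable outcome. For compound 4 the expected value in this assay is therefore 100000 nM, within 50000 nM to 200000 nM, which amounts to an expected step of a number no higher from compound 3 to compound 4 (the limit leaves the size open).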

Compound 4, half-maximal inhibitory concentration: > 100000 nM
Compound 4: only a limit was reported; the forecaster's own chance of this, stated with the estimate: 70%; the middle value sits exactly at the limit.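

Chloro in place of fluoro on the 4-phenyl ring, para to a large group, leaves compound 4 at a limit of the assay in this assay, and not at a number, so methyl, fluoro and chloro at this position all give limits in the compounds shown. Among the compounds shown here, the only readable step for the new compound is an at least 1.2-fold higher number from compound 1 to compound 4 (0.09 log units; that floor lies within the scatter), so compound 4 is not separated from compound 1 beyond the scatter, and the 3-ethylphenyl amide of compound 1 remains the only compound here with a numerical reading. The steps to compound 4 from compound 2 and from compound 3 cannot be read because each has a limit at both ends: the limit of > 100000 nM in this assay, at which 3 of the 4 values shown sit.

Going by these compounds, whether methyl, fluoro and chloro differ from one another at this position remains open, as this assay gives no numbers to compare for these three compounds. Also open, on these data alone, is whether an amine, a carboxylic acid or a methoxy group at the same position would give a numerical reading, and whether a chloro group on the ring position carrying ethyl in compound 1 would do so.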